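A Hydroxyethylamine Swap on a Coumarin Amide Side Chain

The source may report more compounds than this note shows. Statements on the series, on what has been measured and on what is new or still open speak of the compounds shown alone.

Measured so far:
Compound 1 `CC(=O)Oc1ccc(C(=O)Nc2cc3ccc(OCC4CCN(C)C4)c(C)c3oc2=O)cc1CC=C(C)C`: 1880 nM
Compound 2 `CCN(CC)CCCOc1ccc2cc(NC(=O)c3ccc(O)c(CC=C(C)C)c3)c(=O)oc2c1C`: 6390 nM

In a functional assay on MCF7 cells (Homo sapiens) for antiproliferative activity (a lower number here means a stronger inhibitor, a higher number a weaker inhibitor), compound 2 gives 6390 nM, the higher of the two numbers seen, so it is the weaker of the pair; compound 1 gives 1880 nM, a gap that lies beyond the usual scatter. Compound 3 `CC(C)=CCc1cc(C(=O)Nc2cc3ccc(OCCCNCCO)c(C)c3oc2=O)ccc1O` has not yet been measured. It differs from compound 2 in one place: (2-hydroxyethyl)amino in place of diethylamino on a saturated chain carbon, three bonds along the chain from an oxygen on an aromatic ring. The amide-linked phenol and the shared core are untouched.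

Among the measured compounds shown here, no measured pair shows what this particular exchange does, so there is no step to lean on. The expectation is a modest step in this assay, with no clear direction beyond the scatter, so compound 3 is estimated at 5000 nM, within a range of 1500 nM to 16000 nM, which means an expected step of a 1.3-fold lower number from compound 2 to compound 3 (0.11 log units; within the scatter).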

Compound 3, half-maximal inhibitory concentration: 1560 nM
Beside the measured number, compound 3's estimate is 3.2-fold (0.51 log units) above it; the range from low to high includes it.
By their numbers in this assay, from the lowest: compounds 3 and 1 (each within the scatter of the next); then compound 2.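

In this assay, replacing diethylamino with (2-hydroxyethyl)amino on a saturated chain carbon, three bonds along the chain from an oxygen on an aromatic ring, gives a 4.1-fold lower number from compound 2 to compound 3 (0.61 log units; beyond the scatter). Among the compounds shown here, this is the first single-place comparison in the set, and it shows that the number responds to the group at this position and that diethylamino is not required for activity here. No measurement shown explains why the number moves.

As far as these compounds go, it remains open whether the gain depends on the hydroxyl group or only on the loss of one ethyl group, a question that ethylamino on the same chain could help settle. Also open, from the compounds shown here alone, are how a morpholine ring would behave at this position and whether a shorter chain would preserve the step.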